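Phenyl for Methyl: A Small Step Repeated

The source may report more compounds than this note shows. Statements on the series, on what has been measured and on what is new or still open speak of the compounds shown alone.

Measured so far in an assay on isolated protein for inhibition of MAP kinase-activated protein kinase 5 (Homo sapiens), read by mobility shift assay, tested at 30 uM; a higher number here means more inhibition at the concentration tested (going by the name of the read-out), a lower number less inhibition:
Compound 1, `Cc1cc2c(c(N)nn2C)c(=O)[nH]1`, gives 5%.
Compound 2, `Cn1nc(N)c2c(=O)[nH]c(-c3ccccc3)cc21`, gives 11%.
Compound 3, `COCCNc1nc(C)cc2c1c(N)nn2C`, gives 5%.

Compound 2 differs from compound 1 in one place: phenyl in place of methyl on an aromatic carbon. That change gave a number 6 percentage points higher from compound 1 to compound 2 (within the scatter), so these two measurements do not separate the compounds. Compound 3 matches compound 1 at the digits given, and both lie within the scatter of compound 2; how the core of compound 3 differs from that of compound 1 is not broken down here. Compound 4, `COCCNc1nc(-c2ccccc2)cc2c1c(N)nn2C`, is not yet measured and differs from compound 3 as phenyl in place of methyl on an aromatic carbon. This is the same kind of change as from compound 1 to compound 2, though here the place is meta to a (2-methoxyethyl)amino group (5 heavy atoms) rather than meta to a group of 1 heavy atom. Because the earlier step was a number 6 percentage points higher from compound 1 to compound 2 (within the scatter), compound 4 is expected to show a step of similar size, a number 5 percentage points higher from compound 3 to compound 4 (within the scatter). The estimate for compound 4 in this assay is 10%, with a likely range from 0% to 25%.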

Compound 4, a percentage reported as inhibition, at one concentration (the size of the read-out at that concentration, not a potency): 1%
Estimate against measurement, compound 4: 9 percentage points above; the range from low to high includes it.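

Phenyl in place of methyl on an aromatic carbon gave a number 4 percentage points lower from compound 3 to compound 4 (within the scatter) in this assay. Set beside the earlier step, this result does not differ from it: the same change on two cores in this assay, a number 6 percentage points higher (within the scatter) from compound 1 to compound 2 and a number 4 percentage points lower (within the scatter) from compound 3 to compound 4, 10 percentage points apart, within the scatter of two such steps. The two cores therefore give no sign that the change behaves differently from one to the other, but neither step stands clear of the scatter, and this does not show that phenyl raises or lowers inhibition on either core.

The compounds shown leave open what an amine or a carboxylic acid would do at this place on the ring, and what a longer chain would do in place of the (2-methoxyethyl)amino group. Each number is also a read-out at one concentration, not a potency.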